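This account rests on a few compounds, and the source may have more. Where it says the series, first, only, none or still open, it means among the compounds named here.

The compound at the centre of this account is compound 2 `CCc1cccc(NC(=O)N[C@@H](C)c2ccccc2)c1`, which in an ADME assay on the whole organism with Oryza sativa as the target, tested at 10 uM (a lower number here means a stronger effect, a higher number a weaker effect of the compound at the concentration tested), gives 86%. That number sits level with compound 3 `CC(C)c1ccc(NC(=O)N[C@@H](C)c2ccccc2)cc1`, which in this assay gives 86%; together the two are the highest of the three values measured. The furthest of the three is compound 1 `CCc1cccc(NC(=O)N[C@H](C)c2ccccc2)c1`, which in this assay gives 36%. Among the measured compounds shown here, the only single-place step among the measured compounds is the one a number 50 percentage points higher from compound 1 to compound 2 (beyond the scatter), a large move, and the two compounds in it share every atom and bond (the fact that compounds 1 and 2 differ only in the configuration as drawn).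

The next compound, compound 4 `C[C@H](NC(=O)Nc1cccc(I)c1)c1ccccc1`, is not yet measured in this assay. Its difference from compound 2 is iodo in place of ethyl on an aromatic carbon. For the measured compounds named here, no measured step bears on this change: the step from compound 1 to compound 2 concerns configuration only, and the two values of compound 2 and compound 3 merely show that two different groups at two different places on the ring give the same number within the scatter. With nothing pointing in either direction, the step expected from compound 2 to compound 4 in this assay is a number 6 percentage points lower from compound 2 to compound 4 (within the scatter), that is, none beyond the scatter. Compound 4 is therefore estimated at 80% in this assay, with a range from 58% to 98%.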

Compound 4, a percentage reported as activity, at one concentration (the size of the read-out at that concentration, not a potency): 93%
For compound 4 the middle estimate is 13 percentage points below the measured one; measured number inside the range.
By their numbers in this assay, from the lowest: compound 1; then compounds 2, 3 and 4 (each within the scatter of the next).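

In this assay, among the compounds shown here, iodo in place of ethyl on an aromatic carbon, meta to a large group, amounts to a number 7 percentage points higher from compound 2 to compound 4 (within the scatter), and this is the first measured step that touches a substituent on this ring rather than the configuration. At this place, then, a single iodine atom and the two carbons of ethyl cannot be told apart in this read-out, although the two groups share no heavy atom, so this carbon takes at least these two groups, neither with a hydrogen-bond donor or acceptor, without a change beyond the scatter. Nothing known about these compounds bears on why the two groups read alike, since the only fact at hand concerns configuration and not this substituent.

What the compounds shown leave open is whether a group that does carry hydrogen-bond donors or acceptors at this place, such as an amine or a carboxylic acid, or a longer chain such as butyl, would stay within the scatter of compound 2 as well. They also leave open whether iodo in place of ethyl would read the same way on compound 1, the one with the opposite configuration as drawn.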